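Shortened Fluorinated Chain on the Carbonyl Oxygen Substituent

This account rests on a few compounds, and the source may have more. Where it says the series, first, only, none or still open, it means among the compounds named here.

Compound 2 `CCCCOC(=O)c1cccc(-c2ccc(OCC)cc2)c1` carries a butoxycarbonyl group on the shared core and gives 61% in an assay on COS-7 cells for inhibition of patatin-like phospholipase domain-containing protein 2 (Mus musculus), tested at 200 uM; on this read-out lower numbers stand for less inhibition and higher numbers for more inhibition at the one concentration tested (going by the name of the read-out). Within the data shown here, this is the higher of the two numbers measured so far; compound 1 `CCNS(=O)(=O)c1cccc(-c2ccc(OCC)cc2)c1`, with an ethylsulfamoyl group on the same aromatic carbon, gives 46%. Among the measured compounds shown here, the only measured step, a number 15 percentage points higher from compound 1 to compound 2 (beyond the scatter), exchanges the whole substituent on that aromatic carbon. Compound 3 `CCOc1ccc(-c2cccc(C(=O)OCC(F)(F)F)c2)cc1` differs from compound 2 elsewhere: trifluoromethyl in place of propyl on a saturated chain carbon bound to an oxygen next to a carbonyl group, so that butoxy becomes 2,2,2-trifluoroethoxy while the carbonyl is kept. For the measured compounds named here, no measured step alters this chain, so the step from compound 1 to compound 2 does not bear on it directly and no direction can be read from the data. The expected outcome for compound 3 is therefore a step of a number 6 percentage points lower from compound 2 to compound 3 (within the scatter) that stays within the scatter, with a wide range. Compound 3 is estimated at 55%, between 35% and 75%.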

Compound 3, a percentage reported as inhibition, at one concentration (the size of the read-out at that concentration, not a potency): 71%
For compound 3 the middle estimate is 16 percentage points below the measured one, and the stated range covers the measured number.
By their numbers in this assay, from the lowest: compound 1; then compounds 2 and 3 (each within the scatter of the next).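

Among these compounds, with the carbonyl kept, the change on the saturated chain carbon bound to an oxygen next to a carbonyl group gives, in this assay, a number 10 percentage points higher from compound 2 to compound 3 (within the scatter) and is the first measured change to this chain. Butyl and 2,2,2-trifluoroethyl therefore cannot be told apart on this read-out, and the position accepts this exchange of chain with no loss beyond the scatter. No available evidence bears on this result.

Among the compounds shown here, a plain ethyl chain on the same oxygen would be needed to separate the shortening of the chain from the presence of fluorine, and the single step here cannot do that. Also open, going by these compounds, is how a longer fluorinated chain, or a free carboxylic acid in place of the ester, would read on the shared core.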